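Ethyl ester of an acid that gave only a limit

This account rests on a few compounds, and the source may have more. Where it says the series, first, only, none or still open, it means among the compounds named here.

Measured in a functional assay on the whole organism with Scenedesmus acutus as the target, with a stated time of 20 h; on this read-out higher numbers stand for weaker inhibition and lower numbers for stronger inhibition:
compound 1, `O=C1C2=C(CCCC2)C(=O)N1c1ccc(Cl)cc1F`: 240 nM
compound 2, `O=C(O)c1cc(N2C(=O)C3=C(CCCC3)C2=O)ccc1Cl`: > 100000 nM (a limit of the assay, not a number)
compound 3, `COC(=O)c1cc(N2C(=O)C3=C(CCCC3)C2=O)ccc1Cl`: 1620 nM

Compound 2 stands at the limit of > 100000 nM in this assay, at which 1 of the 3 values shown sits; for it there is only a limit and no number. Compound 4, `CCOC(=O)c1cc(N2C(=O)C3=C(CCCC3)C2=O)ccc1Cl`, has not yet been measured in this assay. It differs from compound 2 by ethyl in place of hydrogen on an oxygen next to a carbonyl group.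

Among the compounds with values here, one measured step bears on this change. From the acid to its methyl ester, the step of an at least 61-fold lower number from compound 2 to compound 3 (1.79 log units; beyond the scatter) is large and leaves the limit behind. The ethyl ester is the same kind of change, carried one carbon further, so a step of comparable size and in the same direction is expected, that is an at least 55-fold lower number from compound 2 to compound 4 (1.74 log units; beyond the scatter). Compound 4 is therefore expected to give about 1800 nM in this assay, within a range from 500 nM to 8000 nM.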

Compound 4, half-maximal inhibitory concentration: 2140 nM
The estimate for compound 4 lay 1.2-fold (0.08 log units) below the measured number; measured number inside the range.
By their numbers in this assay, from the lowest: compound 1; then compounds 3 and 4 (each within the scatter of the next). At a limit, above all of these: compound 2.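

In this assay, the escape from the acid's limit is not confined to the methyl ester, since the ethyl ester shows it too, with an at least 46-fold lower number from compound 2 to compound 4 (1.66 log units; beyond the scatter). Compound 2 holds only a limit of the assay, not a number, so this step is bounded on one side only: the limit of > 100000 nM in this assay, at which 1 of the 4 values shown sits. Methyl and ethyl on the oxygen next to the carbonyl group cannot be told apart, with a 1.3-fold higher number from compound 3 to compound 4 (0.12 log units; within the scatter), so the two esters read alike here.

The compounds shown leave open whether a longer chain or a benzyl group on this oxygen would still read like methyl and ethyl, and whether an amide in place of the ester would also leave the limit behind. As far as these compounds go, the true size of the step from the acid also stays open.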